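From 4-methylphenyl to 2,4-dichlorophenyl: a small expected step

The source may report more compounds than this note shows. Statements on the series, on what has been measured and on what is new or still open speak of the compounds shown alone.

In a functional assay on SW-620 cells (Homo sapiens) for inhibition, read by MTT assay, with a stated time of 48 h (a lower number here means a stronger inhibitor, a higher number a weaker inhibitor), compound 3 `Cc1ccc(COc2ccc(C(=O)NC(=S)Nc3ccc(C)c(-c4nc5ccccc5[nH]4)c3)cc2)cc1` gives 60900 nM. Among the compounds with values here, that is the higher of the two true numbers so far: compound 2 `Cc1ccc(NC(=S)NC(=O)c2ccc(OCc3cccc(C(F)(F)F)c3)cc2)cc1-c1nc2ccccc2[nH]1` gives 15400 nM. The gap between them is a 4.0-fold higher number from compound 2 to compound 3 (0.60 log units; beyond the scatter). Compound 1 `Cc1ccc(NC(=S)NC(=O)c2ccc(OCc3cccc(Cl)c3)cc2)cc1-c1nc2ccccc2[nH]1` gives > 100000 nM, which is a limit of the assay and not a number.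

Compound 4 `Cc1ccc(NC(=S)NC(=O)c2ccc(OCc3ccc(Cl)cc3Cl)cc2)cc1-c1nc2ccccc2[nH]1` keeps the shared core and changes one group: 2,4-dichlorophenyl in place of 4-methylphenyl on a saturated chain carbon bound to an oxygen on an aromatic ring. Here, 2,4-dichlorophenyl stands in place of 4-methylphenyl on a saturated chain carbon bound to an oxygen on an aromatic ring.

The measured steps at this same group are an at least 6.4-fold lower number from compound 1 to compound 2 (0.81 log units; beyond the scatter) and an at least 1.6-fold lower number from compound 1 to compound 3 (0.21 log units; that floor lies within the scatter). Compound 1 also carries chloro on this group and ended at a limit, but one chloro compound is thin support for any direction. No step beyond the scatter is therefore expected, and the estimated change is a 1.2-fold lower number from compound 3 to compound 4 (0.09 log units; within the scatter). Compound 4 is estimated at 50000 nM, with an expected range of 15000 nM to 100000 nM.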

Compound 4, half-maximal inhibitory concentration: 57200 nM
Estimate against measurement, compound 4: 1.1-fold (0.06 log units) below, and the stated range covers the measured number.
By their numbers in this assay, from the lowest: compound 2; then compounds 4 and 3 (each within the scatter of the next). At a limit, above all of these: compound 1.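

Compound 4 and compound 3 sit within the scatter of each other in this assay (a 1.1-fold lower number from compound 3 to compound 4 (0.03 log units; within the scatter)), so two quite different rings at this position, 2,4-dichlorophenyl and 4-methylphenyl, give matching results. Compound 2 keeps its separate place, with a 3.7-fold higher number from compound 2 to compound 4 (0.57 log units; beyond the scatter), which makes 3-(trifluoromethyl)phenyl the only group shown that stands apart from both. The step of an at least 1.7-fold lower number from compound 1 to compound 4 (0.24 log units; that floor lies within the scatter) sets no order between these two compounds, and compound 1 remains a limit and not a number: the limit of > 100000 nM in this assay, at which 1 of the 4 values shown sits.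

The compounds shown cannot separate the effect of each chlorine in compound 4, as 4-chlorophenyl is not among them. They also leave open whether an amine or a carboxylic acid on this ring would fall nearer compound 2 or nearer compound 3.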